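The source may hold more compounds than are shown below. What is called first, only, known or untested is meant among the compounds shown, and "the series" means these compounds.

In a functional assay on HCT-15 cells (Homo sapiens) for cytotoxicity, read by ELISA, with a stated time of 2 days (a higher number here means a weaker inhibitor, a lower number a stronger inhibitor), compound 1 (`Oc1cccc(-c2cc(-c3ccccc3)cc(-c3ccsc3)n2)c1`) gives 7660 nM, compound 2 (`Oc1ccc(-c2cc(-c3ccccc3)cc(-c3cccs3)n2)cc1`) gives 12500 nM and compound 3 (`Oc1cccc(-c2cc(-c3ccccc3)nc(-c3cccs3)c2)c1`) gives 14100 nM. Compound 3 therefore stands within the scatter of both other compounds, and the three cannot be ranked. Compound 4 (`Oc1cccc(-c2cc(-c3ccccc3)nc(-c3ccccn3)c2)c1`) has pyridin-2-yl in place of the thiophen-2-yl of compound 3, on an aromatic carbon next to the ring nitrogen (pyridin-2-yl in place of thiophen-2-yl on an aromatic carbon). Among the measured compounds shown here, no measured pair differs in one place, so the data offer no direct precedent for this change. Starting from compound 3 at 14100 nM, no shift beyond the scatter is expected in this assay. The estimated change is a 1.3-fold lower number from compound 3 to compound 4 (0.11 log units; within the scatter). For compound 4, the estimated value is 11000 nM, with an expected range of 4500 nM to 28000 nM.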

Compound 4, half-maximal inhibitory concentration: 20900 nM
Compound 4: the middle estimate sits 1.9-fold (0.28 log units) below what was measured; the range from low to high includes it.
By their numbers in this assay, from the lowest: compounds 1, 2, 3 and 4 (each within the scatter of the next, the first and the last beyond it).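

In this assay, placing pyridin-2-yl in place of thiophen-2-yl on this aromatic carbon next to the ring nitrogen gives a 1.5-fold higher number from compound 3 to compound 4 (0.17 log units; within the scatter) and so stays within the scatter. Among the compounds shown here, this gives the first direct comparison at this position, and here the six-membered and five-membered aromatic rings cannot be told apart. Nothing available explains this result.

Going by these compounds, it remains open whether an amine, a carboxylic acid or a longer chain on this carbon would shift the number in this assay beyond the scatter.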